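The source may hold more compounds than are shown below. What is called first, only, known or untested is meant among the compounds shown, and "the series" means these compounds.

Values in a functional assay on HCT-116 cells (Homo sapiens) for antiproliferative activity, read by MTT assay, with a stated time of 48 h (on this read-out higher numbers stand for weaker inhibition and lower numbers for stronger inhibition), as measured so far:
- compound 1 `CCCCCCC[C@H](CCO)n1cnc2c(Cl)ncnc21` gives 2670 nM
- compound 2 `CCCCCCCCC[C@H](CCO)n1cnc2c(Cl)ncnc21` gives 450 nM
- compound 3 `CCCCCCCCCC(CCO)n1cnc2c(Cl)ncnc21` gives 890 nM

Compound 2 stands clear of compound 1, as shown by a 5.9-fold lower number from compound 1 to compound 2 (0.77 log units; beyond the scatter). Against compound 3 it cannot be ranked, as a 2.0-fold higher number from compound 2 to compound 3 (0.30 log units; within the scatter) shows, and that pair differs only in the fact that one of compounds 2 and 3 is drawn with a defined configuration and the other without, at the place where they differ.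

Compound 4 `CCCCCCCCC[C@H](CCn1cc(-c2ccccc2)nn1)n1cnc2c(Cl)ncnc21` departs from compound 2 in another way: 4-phenyl-1H-1,2,3-triazol-1-yl in place of hydroxy on a saturated chain carbon, three bonds along the chain from an aromatic nitrogen. Here 4-phenyl-1H-1,2,3-triazol-1-yl takes the place of hydroxy on a saturated chain carbon, three bonds along the chain from an aromatic nitrogen. For the measured compounds named here, no measured step touches this change, so its effect has no direct precedent in these data. Going by the values given here, the only guide to size is a 5.9-fold lower number from compound 1 to compound 2 (0.77 log units; beyond the scatter), which came from ethyl in place of hydrogen on a saturated chain carbon. That step shows that a change in the chain can move the number in this assay beyond the scatter. A step of similar modest size is therefore expected, leaning towards a higher number, though the direction is uncertain. The expected change is a 2.4-fold higher number from compound 2 to compound 4 (0.39 log units; beyond the scatter). Compound 4 is estimated at 1100 nM, with an expected range from 250 nM to 5500 nM.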

Compound 4, half-maximal inhibitory concentration: 8130 nM
The estimate for compound 4 lay 7.4-fold (0.87 log units) below the measured number; measured number outside the range, above it.
By their numbers in this assay, from the lowest: compounds 2 and 3 (each within the scatter of the next); then compound 1; then compound 4.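

For the compounds shown here, at the saturated chain carbon three bonds along the chain from an aromatic nitrogen, the earlier compounds all carry hydroxy, so they gave no view of how this place responds to change. In this assay, the replacement by 4-phenyl-1H-1,2,3-triazol-1-yl gives an 18-fold higher number from compound 2 to compound 4 (1.26 log units; beyond the scatter), which shows that this place is not indifferent to what it carries and that this group is poorly tolerated here. The change removes the hydrogen-bond donor of hydroxy and brings in two aromatic rings in a single step, so the data cannot divide the effect among these differences, and nothing available accounts for the size of the step.

As far as these compounds go, it remains open whether hydroxy itself matters at this place, or whether an amine, a carboxylic acid or a 1H-1,2,3-triazol-1-yl group without its phenyl would keep the number close to that of compound 2. Also open, from the compounds shown here alone, is whether a longer chain at the other end of the molecule would change how much the 4-phenyl-1H-1,2,3-triazol-1-yl group costs.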